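Oxan-4-yl in place of benzyl on an amine nitrogen

This account rests on a few compounds, and the source may have more. Where it says the series, first, only, none or still open, it means among the compounds named here.

In an ADME assay on A549 cells (Homo sapiens) for cytotoxicity, read by CellTiter-Glo (on this read-out higher numbers stand for lower toxicity in this test and lower numbers for higher toxicity in this test), compound 1 `Cc1c(Cc2ccccc2)c(=O)oc2cc(OCC(O)CNCC3CC3)ccc12` reads > 100000 nM, which is a limit and not a number. Compound 2 `Cc1c(Cc2ccccc2)c(=O)oc2cc(OCC(O)CNc3ccc(Br)cc3)ccc12` reads > 100000 nM, again a limit. Compound 3 `Cc1c(Cc2ccccc2)c(=O)oc2cc(OCC(O)CNCc3ccccc3)ccc12` reads > 100000 nM, also a limit, so compound 3 has no exact number of its own. All the evidence so far rests on (the limit of > 100000 nM in this assay, at which 3 of the 3 values shown sit).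

Compound 4 `Cc1c(Cc2ccccc2)c(=O)oc2cc(OCC(O)CNC3CCOCC3)ccc12` keeps the shared core and carries oxan-4-yl in place of benzyl on an amine nitrogen.

Three measured changes also alter the group on the amine. None of them gives a size: there is a step that the two limits leave unreadable from compound 1 to compound 2, then a step that the two limits leave unreadable from compound 1 to compound 3, and finally a step that the two limits leave unreadable from compound 2 to compound 3. They therefore point to no shift in either direction beyond the usual scatter. The expected change is a number no higher from compound 3 to compound 4 (the limit leaves the size open), and no clear direction is expected for it.

Compound 4 is estimated at 100000 nM, with an expected range of 50000 nM to 200000 nM.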

Compound 4, half-maximal cytotoxic concentration: 38200 nM
Estimate against measurement, compound 4: 2.6-fold (0.42 log units) above; measured number below the stated range.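

In this assay, the group on the amine nitrogen now visibly matters: oxan-4-yl brings an at least 2.6-fold lower number from compound 3 to compound 4 (0.41 log units; beyond the scatter), as well as an at least 2.6-fold lower number from compound 2 to compound 4 (0.41 log units; beyond the scatter) and an at least 2.6-fold lower number from compound 1 to compound 4 (0.41 log units; beyond the scatter). The steps among compound 1, compound 2 and compound 3 cannot be read, so compound 4 gives the first sign of higher toxicity in this series, and the first exact number. Each new step gives only a minimum size, not an exact one: the limit of > 100000 nM in this assay, at which 3 of the 4 values shown sit.

The compounds shown leave open whether the oxygen of oxan-4-yl or the non-aromatic ring itself goes with the lower number. A cyclohexyl group on the same amine nitrogen, which keeps a six-membered non-aromatic ring without the oxygen, would separate these two possibilities.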